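This account rests on a few compounds, and the source may have more. Where it says the series, first, only, none or still open, it means among the compounds named here.

Among the compounds with values here, in a functional assay on CNS cells (Homo sapiens) for antiproliferative activity (on this read-out higher numbers stand for weaker inhibition of growth and lower numbers for stronger inhibition of growth), compound 3 `N=C(N)N/N=C/c1c(-c2ccccn2)nc2sc(Cl)cn12` gives 11500 nM, the lowest of the three numbers so far. Compound 2 `Cc1sc2nc(-c3ccccn3)c(/C=N/NC(=N)N)n2c1C` gives 41700 nM, and compound 1 `Cc1sc2nc(-c3ccncc3)c(/C=N/NC(=N)N)n2c1C` gives 93300 nM. Compound 4 `N=C(N)N/N=C/c1c(-c2ccncc2)nc2sc(Cl)cn12` differs from compound 3 by having pyridin-4-yl in place of pyridin-2-yl on an aromatic carbon. Within the data shown here, only one measured step bears on this, and it ran the opposite way, with pyridin-2-yl replacing pyridin-4-yl: a 2.2-fold lower number from compound 1 to compound 2 (0.35 log units; beyond the scatter). That step was modest and was seen on a slightly different core, so reversing it here should raise the number by a similar, modest amount. The expected change is a 2.2-fold higher number from compound 3 to compound 4 (0.34 log units; beyond the scatter). For compound 4 the estimated value is 25000 nM, with an expected range of 11000 nM to 60000 nM.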

Compound 4, concentration for total growth inhibition: 20000 nM
Beside the measured number, compound 4's estimate is 1.3-fold (0.10 log units) above it; measured number inside the range.
By their numbers in this assay, from the lowest: compounds 3 and 4 (each within the scatter of the next); then compound 2; then compound 1.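

In this assay, the change of pyridin-2-yl to pyridin-4-yl at this position gives a 1.7-fold higher number from compound 3 to compound 4 (0.24 log units; within the scatter), so on this core the two groups cannot be told apart. The earlier compounds showed this change on only one core; it can now be compared on two, and the two steps agree in size: the same change on two cores in this assay, a 2.2-fold lower number (0.35 log units; beyond the scatter) from compound 1 to compound 2 and a 1.7-fold lower number (0.24 log units; within the scatter) from compound 4 to compound 3, 1.3-fold (0.11 log units) apart, within the scatter of two such steps

Among the compounds shown, only these two pyridine groups sit at this position. Going by these compounds, how a pyridin-3-yl group, a phenyl ring or an amine would behave there remains open.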